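A few compounds are considered here, and "the series" means these few. Any claim that something is new, unique, unknown or untested is made for them only; others in the source may bear on it.

Measured compounds:
compound 1, `C[C@@H](NC(=O)c1cnc(C#Cc2cccc(F)c2)cn1)C(C)(C)O`, 17.2%
compound 2, `C[C@@H](NC(=O)c1ccc(C#Cc2cccc(F)c2)cn1)C(C)(C)C`, 31.2%
compound 3, `C[C@H](NC(=O)c1ccc(C#Cc2cccc(F)c2)cn1)C(C)(C)C`, 20%

In an ADME assay on HEK293 cells for agonist activity at metabotropic glutamate receptor 5 (Rattus norvegicus), read by fluorescence and calcium flux (a higher number here means a larger maximal response, a lower number a smaller maximal response), compound 3 stands second highest of the three numbers. Its nearest neighbour is compound 1, which gives 17.2% in this assay, a gap within the scatter of such measurements. Its furthest is compound 2, which gives 31.2%, a gap beyond the scatter. For the measured compounds named here, the single step that can be compared here is a number 11.2 percentage points lower from compound 2 to compound 3 (beyond the scatter), and it rests on (the fact that compounds 2 and 3 differ only in the configuration as drawn).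

Compound 4, `CC(C)[C@@H](C)NC(=O)c1ccc(C#Cc2cccc(F)c2)cn1`, is not yet measured in this assay. It differs from compound 3 by 1,2-dimethylpropyl in place of 1,2,2-trimethylpropyl on an amide-type nitrogen. Going by the values given here, this change is not the stereo inversion seen between compound 2 and compound 3, so the step of a number 11.2 percentage points lower from compound 2 to compound 3 (beyond the scatter) does not speak to it directly; no measured pair covers a change in the size of the alkyl group on the amide-type nitrogen. With nothing to point either way, the expectation is for compound 4 to stay close to compound 3, with a step of a number 1 percentage points higher from compound 3 to compound 4 (within the scatter) that is expected to remain within the scatter. Compound 4 is therefore estimated at 21%, with a range from 9% to 35%.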

Compound 4, largest response reached (reported as efficacy), in percent of the reference or control that the assay uses: 22.5%
Beside the measured number, compound 4's estimate is 1.5 percentage points below it; the measured number falls inside the stated range.
By their numbers in this assay, from the lowest: compounds 1, 3, 4 and 2 (each within the scatter of the next, the first and the last beyond it).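

In this assay, the position on the amide-type nitrogen tolerates 1,2-dimethylpropyl in place of 1,2,2-trimethylpropyl, with the new result giving a number 2.5 percentage points higher from compound 3 to compound 4 (within the scatter). Compound 4 also lies close to compound 2, with a number 8.7 percentage points lower from compound 2 to compound 4 (within the scatter), so it does not separate the two compounds whose drawn configurations gave a number 11.2 percentage points lower from compound 2 to compound 3 (beyond the scatter), a gap beyond the scatter. For the compounds shown here, nothing at hand gives a cause for the two new steps, and within the scatter they show only that this change in the alkyl group leaves no clear mark on the maximal response.

The compounds shown leave open how the opposite drawn configuration of the 1,2-dimethylpropyl group would read in this assay, and so whether configuration matters for this group as it did for 1,2,2-trimethylpropyl. They also leave open whether a cyclopropyl group, a longer chain or a chain carrying an amine on the amide-type nitrogen would move the maximal response beyond the scatter.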